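Swapping hydroxymethyl for acetamido on a low-exposure tetrazole

This account rests on a few compounds, and the source may have more. Where it says the series, first, only, none or still open, it means among the compounds named here.

Measured compounds:
compound 1 `CCCCN(c1nc2c(CO)cccc2o1)[C@H](C)c1ccc(-c2ccccc2-c2nnn[nH]2)cc1`: 20 ng.h/mL
compound 2 `Cc1ccc(-c2nc(=O)o[nH]2)c(-c2ccc([C@@H](C)N(CC3CC3)c3nc4c(C(=O)O)cccc4o3)cc2)c1`: 4830 ng.h/mL

In an ADME assay on the whole organism (Macaca fascicularis) for pharmacokinetics, read by LC-MS, using cassette dosing, at a dose of 1 mg/kg by the oral route (on this read-out lower numbers stand for lower exposure and higher numbers for higher exposure at the dose given), compound 1 gives 20 ng.h/mL, the lowest of the two numbers; compound 2 gives 4830 ng.h/mL, a gap well beyond the scatter. Compound 3 `CCCCN(c1nc2c(NC(C)=O)cccc2o1)[C@H](C)c1ccc(-c2ccccc2-c2nnn[nH]2)cc1` differs from compound 1 by acetamido in place of hydroxymethyl on an aromatic carbon. For the measured compounds named here, no measured pair shows this change, so the size of its step is uncertain. Because compound 1 sits at 20 ng.h/mL, the expected step is a 1.8-fold higher number from compound 1 to compound 3 (0.24 log units; within the scatter). Compound 3 is estimated at 35 ng.h/mL, within 6 ng.h/mL to 200 ng.h/mL.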

Compound 3, area under the concentration-time curve: 41.6 ng.h/mL
Estimate against measurement, compound 3: 1.2-fold (0.08 log units) below, within the range that was stated.
By their numbers in this assay, from the lowest: compound 1; then compound 3; then compound 2.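

In this assay, placing acetamido instead of hydroxymethyl on this aromatic carbon gives a 2.1-fold higher number from compound 1 to compound 3 (0.32 log units; beyond the scatter), a modest step. The position therefore tolerates a group with more heavy atoms without losing exposure, even though the hydrogen-bond donor and acceptor counts stay the same. Nothing shown here explains why the number rises. On these data alone, what a carboxylic acid or an amine on this same aromatic carbon would give remains open. As far as these compounds go, it is also open whether this swap would give a similar step on a different core.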